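Back From the Limit: an Amide-Linked Aryl Returns

The source may hold more compounds than are shown below. What is called first, only, known or untested is meant among the compounds shown, and "the series" means these compounds.

Of the compounds shown here, three sharing one core have been tested in a functional assay on MCF7 cells (Homo sapiens) for inhibition, read by MTT assay, with a stated time of 24 h; on this read-out lower numbers stand for stronger inhibition and higher numbers for weaker inhibition. Compound 1 `CCOC(=O)C1=Cc2ccccc2OC1(OCc1cn(-c2ccc(F)cc2)nn1)C(F)(F)F` gives 9100 nM in this assay. Compound 2 `CCOC(=O)C1=Cc2ccccc2OC1(OCc1cn(CC(=O)Nc2cccc(Cl)c2)nn1)C(F)(F)F` carries ((3-chlorophenyl)carbamoyl)methyl in place of 4-fluorophenyl on an aromatic nitrogen, and in this assay compound 2 gives 11600 nM. That is a small change: a 1.3-fold higher number from compound 1 to compound 2 (0.11 log units; within the scatter). Compound 3 `CCOC(=O)C1=Cc2ccccc2OC1(OCc1cn(-c2cccc(C(F)(F)F)c2)nn1)C(F)(F)F` reaches only the limit of this assay, > 150000 nM. Compound 3 thus sits at the limit of > 150000 nM in this assay, at which 1 of the 3 values shown sits, and stands apart from the other two: an at least 16-fold higher number from compound 1 to compound 3 (1.21 log units; beyond the scatter), and likewise an at least 12-fold higher number from compound 2 to compound 3 (1.11 log units; beyond the scatter).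

Compound 4 `CCOC(=O)C1=Cc2ccccc2OC1(OCc1cn(CC(=O)Nc2cccc(F)c2)nn1)C(F)(F)F` has not yet been measured. Its difference from compound 3 is ((3-fluorophenyl)carbamoyl)methyl in place of 3-(trifluoromethyl)phenyl on an aromatic nitrogen. Among the measured compounds shown here, the measured step that bears most directly on it is the one from compound 2 to compound 3, which exchanged a carbamoylmethyl-linked aryl for a directly attached aryl and was large. Compound 4 undoes that kind of change and differs from compound 2 only by fluorine in place of chlorine on the pendant ring. A large step toward stronger inhibition in this assay, meaning a lower number, is therefore expected. The expected step from compound 3 to compound 4 is an at least 12-fold lower number from compound 3 to compound 4 (1.09 log units; beyond the scatter). Compound 4 is estimated at 12000 nM, within a range of 4000 nM to 40000 nM.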

Compound 4, half-maximal inhibitory concentration: > 150000 nM
Compound 4 gave a limit, no number; the forecaster's own chance of this, stated with the estimate: 10%; middle value at least 12-fold (1.09 log units) from the limit.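

The carbamoylmethyl link alone does not secure a measurable value in this assay; with fluoro in place of chloro on an aromatic carbon, the result is an at least 12-fold higher number from compound 2 to compound 4 (1.11 log units; beyond the scatter). A fluorine-bearing aryl ring does not secure one either, as the exchange of 4-fluorophenyl for ((3-fluorophenyl)carbamoyl)methyl on an aromatic nitrogen gives an at least 16-fold higher number from compound 1 to compound 4 (1.21 log units; beyond the scatter). Compound 3 and compound 4 each give only a limit, so the step between them cannot be read, and each kind of link, direct or through the carbamoylmethyl group, now holds one measured compound and one at that limit: the limit of > 150000 nM in this assay, at which 2 of the 4 values shown sit.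

Still open is whether the loss belongs to fluoro in particular, since the amide-linked aryl rings shown carry only chloro or fluoro, and a bromo or methyl group in the same place, or a plain phenyl ring, would test this. Also open, as far as these compounds go, is whether a longer chain between the five-membered ring and the amide, or a carboxylic acid in place of the aryl amide, would give a measurable number in this assay.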